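The compounds below may be only part of what the source reports. "The series", "measured", "known", "first", "only" and "open" are said of these compounds alone.

Measured compounds:
compound 1 `c1ccc2c(c1)CN[C@@H](CN(CCC1CCNCC1)[C@H]1CCCc3cccnc31)C2` gives 150 nM in a functional assay on CCRF-CEM cells for antagonist activity at C-X-C chemokine receptor type 4 (Homo sapiens), read by calcium flux, with stated times of 25 min and 90 s; on this read-out lower numbers stand for stronger inhibition and higher numbers for weaker inhibition;
compound 2 `CCN1CCN(CCCN(C[C@H]2Cc3ccccc3CN2)[C@H]2CCCc3cccnc32)CC1` gives 33 nM in this assay;
compound 3 `c1ccc2c(c1)CN[C@@H](CN(CCCN1CCN(C3CC3)CC1)[C@H]1CCCc3cccnc31)C2` gives 50 nM in this assay.

On these numbers compound 3 stands second of the three, close to compound 2 and clearly apart from compound 1, as the steps of a 1.5-fold higher number from compound 2 to compound 3 (0.18 log units; within the scatter) and a 3.0-fold lower number from compound 1 to compound 3 (0.48 log units; beyond the scatter) show. Compound 4 `c1ccc2c(c1)CN[C@@H](CN(CCCCN1CCNCC1)[C@H]1CCCc3cccnc31)C2` has not yet been measured. It differs from compound 3 by (piperazin-1-yl)methyl in place of 4-cyclopropylpiperazin-1-yl on a saturated chain carbon, three bonds along the chain from an amine nitrogen. Within the data shown here, two measured steps bear on this. The exchange of the basic terminal group in a 4.5-fold lower number from compound 1 to compound 2 (0.66 log units; beyond the scatter) and a 3.0-fold lower number from compound 1 to compound 3 (0.48 log units; beyond the scatter) moved the numbers modestly, while the exchange of the substituent on the ring nitrogen in a 1.5-fold higher number from compound 2 to compound 3 (0.18 log units; within the scatter) stayed within the scatter. Among the measured compounds shown here, no measured pair shows the chain lengthened by one carbon or the ring nitrogen left unsubstituted together, so the outcome is uncertain. Compound 4 is expected to sit near compound 3, its number estimated at 80 nM with a range from 30 nM to 250 nM, the expected step being a 1.6-fold higher number from compound 3 to compound 4 (0.20 log units; within the scatter).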

Compound 4, half-maximal inhibitory concentration: 66 nM
Compound 4: the middle estimate sits 1.2-fold (0.08 log units) above what was measured, and the stated range covers the measured number.
By their numbers in this assay, from the lowest: compounds 2, 3 and 4 (each within the scatter of the next); then compound 1.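

In this assay, the 2-(piperazin-1-yl)ethyl group, which carries a hydrogen-bond donor and no group on its ring nitrogen, reads level with the substituted piperazines, since both a 1.3-fold higher number from compound 3 to compound 4 (0.12 log units; within the scatter) and a 2.0-fold higher number from compound 2 to compound 4 (0.30 log units; within the scatter) remain within the scatter. The step of a 2.3-fold lower number from compound 1 to compound 4 (0.36 log units; beyond the scatter) adds a third piperazine-bearing compound that stands apart from the piperidin-4-yl compound, and none of the compounds shown goes against this. No measurement offered here accounts for these results.

The compounds shown do not separate the one-carbon change in chain length from the loss of the group on the ring nitrogen, as the two occur together in this step. Also open, on these data alone, is how a morpholine ring or a still longer chain would read in this place.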